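From 2-methylphenyl to 4-fluorobenzyl on compound 1

A few compounds are considered here, and "the series" means these few. Any claim that something is new, unique, unknown or untested is made for them only; others in the source may bear on it.

Measured so far in an ADME assay on L02 cells (Homo sapiens) for inhibition, read by CCK-8 assay, with a stated time of 48 h; a higher number here means a weaker inhibitor of growth, a lower number a stronger inhibitor of growth:
- Compound 1 `Cc1ccccc1Nc1nc(Nc2ccc(N3CCN(C)CC3)cn2)ncc1Cl` gives 5980 nM as its value
- Compound 2 `Cc1ccccc1Nc1nc(Nc2ccc(N3CCCCC3)cn2)ncc1Cl` gives 42400 nM as its value

Compound 1 holds the lower of these two numbers, and so is the stronger inhibitor of growth of the pair. For the measured compounds named here, the gap between them is the only measured step, a 7.1-fold higher number from compound 1 to compound 2 (0.85 log units; beyond the scatter), where piperidin-1-yl stands in place of 4-methylpiperazin-1-yl on an aromatic carbon.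

Compound 3 `CN1CCN(c2ccc(Nc3ncc(Cl)c(NCc4ccc(F)cc4)n3)nc2)CC1` keeps that 4-methylpiperazin-1-yl group but differs from compound 1 elsewhere: 4-fluorobenzyl in place of 2-methylphenyl on a nitrogen on an aromatic ring. Here 4-fluorobenzyl stands in place of 2-methylphenyl on a nitrogen on an aromatic ring.

The measured step lies at another place, so it bears only indirectly, as a guide to how far one exchange can move this assay. Going by the values given here, no measured pair varies the 2-methylphenyl group, which leaves the direction uncertain. Since compound 1 sits at the lower end with 5980 nM, a modest rise is the more likely outcome. The expected change is a 1.8-fold higher number from compound 1 to compound 3 (0.26 log units; within the scatter), no larger than the measured step. For compound 3 the estimated value is 11000 nM, with an expected range from 3000 nM to 40000 nM.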

Compound 3, concentration for 50% growth inhibition: 39700 nM
Compound 3: the middle estimate sits 3.6-fold (0.56 log units) below what was measured; the measured number falls inside the stated range.
By their numbers in this assay, from the lowest: compound 1; then compounds 3 and 2 (each within the scatter of the next).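

In this assay, the group on this nitrogen turns out to matter: replacing (2-methylphenyl)amino with (4-fluorobenzyl)amino gives a 6.6-fold higher number from compound 1 to compound 3 (0.82 log units; beyond the scatter), so the number moves well past the scatter at this place too, not only at the 4-methylpiperazin-1-yl group. The exchange at the other place gives a 7.1-fold higher number from compound 1 to compound 2 (0.85 log units; beyond the scatter), and compound 1 therefore holds the lower number in both single-place comparisons, each step leading to a weaker inhibitor of growth in this L02 cell read-out. Nothing shown here offers an explanation for the rise on the nitrogen.

This single exchange alters the group in more than one way at once, so the compounds shown do not separate the loss of the 2-methylphenyl group from the entry of the fluorine or of the benzyl link. On these data alone, a plain phenyl or an unsubstituted benzyl on the same nitrogen would bear on that question, and it also stays open whether a 4-fluorophenyl there would give a number closer to that of compound 1 or to that of compound 3.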